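Chloro to Trifluoromethyl on the Phenoxy Ring: Lipophilicity

This account rests on a few compounds, and the source may have more. Where it says the series, first, only, none or still open, it means among the compounds named here.

In a physicochemical assay for lipophilicity, read by HPLC, tested at 5 mM (on this read-out higher numbers stand for higher lipophilicity and lower numbers for lower lipophilicity), compound 1 `CCCCCCCCc1ccc(OC(C)C(=O)Cn2nnc(-c3ccccc3)n2)cc1` sits at a limit of the method rather than a number, > 8, as the line the limit of > 8 in this assay, at which 1 of the 3 values shown sits, records. Compound 2 `CC(Oc1ccc(Oc2ccc(F)cc2)cc1)C(=O)Cn1nnc(-c2ccccc2)n1` gives 5.3, and compound 3 `CC(Oc1ccc(Oc2ccc(Cl)cc2)cc1)C(=O)Cn1nnc(-c2ccccc2)n1` gives 6, the higher of the two numbers; the step is a number 0.70 log units higher from compound 2 to compound 3 (beyond the scatter). Compound 4 `CC(Oc1ccc(Oc2ccc(C(F)(F)F)cc2)cc1)C(=O)Cn1nnc(-c2ccccc2)n1` is not yet measured and differs from compound 3 by trifluoromethyl in place of chloro on an aromatic carbon. For the measured compounds named here, the one measured step that bears on this exchange is a number 0.70 log units higher from compound 2 to compound 3 (beyond the scatter), a modest rise; the steps of a number at least 2.70 log units lower from compound 1 to compound 2 (beyond the scatter) and a number at least 2.00 log units lower from compound 1 to compound 3 (beyond the scatter) start from a limit and set no size. The expected step is a further modest rise, a number 0.40 log units higher from compound 3 to compound 4 (beyond the scatter). Compound 4 is therefore estimated at 6.4, between 5.9 and 7.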

Compound 4, partition coefficient: 6.2
The estimate for compound 4 lay 0.20 log units above the measured number; the measured number falls inside the stated range.
By their numbers in this assay, from the lowest: compound 2; then compounds 3 and 4 (each within the scatter of the next). At a limit, above all of these: compound 1.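

In this assay the step of a number 0.20 log units higher from compound 3 to compound 4 (within the scatter) shows that trifluoromethyl and chloro cannot be told apart at this position, while fluoro can. The step of a number 0.90 log units higher from compound 2 to compound 4 (beyond the scatter) is of the same modest kind as the rise seen with chloro, so of these three groups fluoro alone stands apart. Compound 1 remains at a limit of the method, so the step of a number at least 1.80 log units lower from compound 1 to compound 4 (beyond the scatter) gives a direction but no exact size.

From the compounds shown here alone, how an amine or a carboxylic acid would read at this position remains open. So does where a chain shorter than octyl would fall.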